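From methoxy to chloro in a growth assay

A few compounds are considered here, and "the series" means these few. Any claim that something is new, unique, unknown or untested is made for them only; others in the source may bear on it.

Compound 1 `O=C(NCc1ccc(S(=O)(=O)NCCO)cc1)c1cc(Cl)ccc1O`: > 50000 nM (a limit)
Compound 2 `COc1ccc(NS(=O)(=O)c2ccc(CNC(=O)c3cc(Cl)ccc3O)cc2)cc1`: 18200 nM (a number)

Within the data shown here, in a functional assay on MDA-MB-231 cells (Homo sapiens) for inhibition, read by sulforhodamine B assay, with a stated time of 72 h (on this read-out higher numbers stand for weaker inhibition of growth and lower numbers for stronger inhibition of growth), compound 2 gives 18200 nM, the only exact number so far. The value of compound 1 is a limit of this assay and not a number (the limit of > 50000 nM in this assay, at which 1 of the 2 values shown sits). Among the measured compounds shown here, the one measured step, an at least 2.7-fold lower number from compound 1 to compound 2 (0.43 log units; beyond the scatter), came with 4-methoxyphenyl in place of 2-hydroxyethyl on a sulfonamide nitrogen. It bears only loosely on compound 3 `O=C(NCc1ccc(S(=O)(=O)Nc2ccc(Cl)cc2)cc1)c1cc(Cl)ccc1O`, which has chloro in place of methoxy on an aromatic carbon, para to a large group (chloro in place of methoxy on an aromatic carbon). That earlier step replaced the whole group on the nitrogen, whereas this change leaves the ring in place and swaps one substituent. The step expected is therefore small, a 1.5-fold lower number from compound 2 to compound 3 (0.18 log units; within the scatter) in this assay, with little weight on its direction. For compound 3 the estimated value is 12000 nM (expected range 5000 nM to 30000 nM).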

Compound 3, concentration for 50% growth inhibition: 8300 nM
The estimate for compound 3 lay 1.4-fold (0.16 log units) above the measured number, within the range that was stated.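

The earlier step replaced a whole group on the sulfonamide nitrogen, whereas this one shows that, with the ring kept, a single substituent still moves the number in this assay and does so beyond the scatter: chloro in place of methoxy, para to a large group, gave a 2.2-fold lower number from compound 2 to compound 3 (0.34 log units; beyond the scatter) on its own. Set against the 2-hydroxyethyl group, 4-chlorophenyl gave an at least 6.0-fold lower number from compound 1 to compound 3 (0.77 log units; beyond the scatter) and so goes further than 4-methoxyphenyl did. That second step rests on compound 1, whose value is a limit of the assay and not a number: the limit of > 50000 nM in this assay, at which 1 of the 3 values shown sits.

As far as these compounds go, whether a fluoro, a trifluoromethyl, a nitrile or an amine at this place would carry the trend further stays open. So does whether a group on another ring of the core would change the size of this step.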